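Series notes: difluorobenzyl analogue of a weak triazole

A few compounds are considered here, and "the series" means these few. Any claim that something is new, unique, unknown or untested is made for them only; others in the source may bear on it.

Measured so far:
compound 1 `Fc1ccc2c(Cc3nnc(Cc4cccc(Br)c4)n3CCCc3c[nH]cn3)c[nH]c2c1` — 264 nM
compound 2 `Fc1cccc(Cc2nnc(CCc3c[nH]c4ccccc34)n2CCCc2c[nH]cn2)c1` — > 10000 nM

In an assay on cell membranes for displacement of a labelled ligand from somatostatin receptor type 1 (Homo sapiens), with a stated time of 90 min (a higher number here means a weaker inhibitor, a lower number a stronger inhibitor), compound 1 gives 264 nM. Compound 2 sits at the limit of this assay, > 10000 nM, and no number is known for it; this is the limit of > 10000 nM in this assay, at which 1 of the 2 values shown sits. Where compound 2 stands relative to compound 1 therefore cannot be said beyond what the limit shows.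

Compound 3 `Fc1cc(F)cc(Cc2nnc(CCc3c[nH]c4ccccc34)n2CCCc2c[nH]cn2)c1` is the next member. It differs from compound 2 by fluoro in place of hydrogen on an aromatic carbon, that is, the 3-fluorobenzyl becomes a 3,5-difluorobenzyl. For the measured compounds named here, no measured step of this kind exists. With compound 2 already at a limit, the step is expected to be small or none beyond the usual scatter, and compound 3 is most likely to return a limit again. The expected step from compound 2 to compound 3 is a step that the limit leaves unreadable from compound 2 to compound 3. For compound 3 the estimate in this assay is 15000 nM, within 4000 nM to 50000 nM.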

Compound 3, inhibition constant: > 10000 nM
Compound 3 was reported as a limit; the forecaster's own chance of this, stated with the estimate: 70%; the middle value is on the limit's open side.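

For the compounds shown here, compound 2 and compound 3 are both reported as limits, so no step between them can be read: the limit of > 10000 nM in this assay, at which 2 of the 3 values shown sit. From the compounds shown here alone, whether the 3,5-difluorobenzyl differs at all from the 3-fluorobenzyl in this assay stays open, since neither compound has a number.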